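Removing the Amine Methyl from a Bis(trifluoromethyl) Sulfonamide

A few compounds are considered here, and "the series" means these few. Any claim that something is new, unique, unknown or untested is made for them only; others in the source may bear on it.

Compound 1 `O=S(=O)(NCCCNCc1ccccc1Cl)c1cc(C(F)(F)F)cc(C(F)(F)F)c1` gives 20000 nM in a functional assay on HT-29 cells (Homo sapiens) for inhibition, read by MTT assay, with a stated time of 72 h; on this read-out higher numbers stand for weaker inhibition of growth and lower numbers for stronger inhibition of growth.
Compound 2 `CC(C)(C)c1ccc(CNCCCNS(=O)(=O)c2cc(C(F)(F)F)cc(C(F)(F)F)c2)cc1` gives 2000 nM in this assay.
Compound 3 `CN(CCCNS(=O)(=O)c1cc(C(F)(F)F)cc(C(F)(F)F)c1)Cc1ccccc1` gives only a limit, > 50000 nM, in this assay.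
Compound 4 `O=S(=O)(NCCCNCc1ccccc1)c1cc(C(F)(F)F)cc(C(F)(F)F)c1` has not yet been measured in this assay.

Going by the values given here, compound 3 stands at the limit of > 50000 nM in this assay, at which 1 of the 3 values shown sits; it is the one compound of the three without a number. The step to compound 4 is hydrogen in place of methyl on an amine nitrogen, so that benzyl(methyl)amino becomes benzylamino and the chain from that nitrogen to the sulfonamide nitrogen is otherwise kept.

Among the compounds with values here, two measured steps bear on this. The step of an at least 2.5-fold higher number from compound 1 to compound 3 (0.39 log units; beyond the scatter) bundles the added methyl with the loss of the chlorine on the benzyl ring, so undoing the methyl alone should recover part of that loss. The step of a 10-fold lower number from compound 1 to compound 2 (1.00 log units; beyond the scatter) shows that the benzyl substituent also moves the number strongly, and compound 4 carries none. Compound 4 is therefore expected to land between compound 3 and compound 1, a step of an at least 1.7-fold lower number from compound 3 to compound 4 (0.25 log units; that floor lies within the scatter) in this assay. The estimate for compound 4 is 28000 nM, within 9000 nM to 90000 nM.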

Compound 4, concentration for 50% growth inhibition: 15000 nM
For compound 4 the middle estimate is 1.9-fold (0.27 log units) above the measured one; measured number inside the range.
By their numbers in this assay, from the lowest: compound 2; then compounds 4 and 1 (each within the scatter of the next). At a limit, above all of these: compound 3.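

Compound 3 is held at a limit, not a number: the limit of > 50000 nM in this assay, at which 1 of the 4 values shown sits. In this assay, hydrogen in place of methyl on the amine nitrogen, now seen alone rather than bundled with the chlorine, gives an at least 3.3-fold lower number from compound 3 to compound 4 (0.52 log units; beyond the scatter), so the methyl on this nitrogen goes with weaker inhibition of growth, and the limit makes this step a floor. The ring substituents now separate: hydrogen in place of chloro on an aromatic carbon gives a 1.3-fold lower number from compound 1 to compound 4 (0.12 log units; within the scatter), whereas hydrogen in place of tert-butyl gives a 7.5-fold higher number from compound 2 to compound 4 (0.88 log units; beyond the scatter), so among these compounds the tert-butyl carries a step beyond the scatter and the chloro does not.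

Going by these compounds, the true size of the methyl step stays open, as does whether it would hold with 4-(tert-butyl)phenyl in place of the plain benzyl ring. On these data alone, whether an ethyl on this nitrogen or a longer chain to the sulfonamide nitrogen would behave alike is also open.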